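The compounds below may be only part of what the source reports. "The series", "measured", "known", "first", "only" and "open" are said of these compounds alone.

Measured compounds:
Compound 3 `CCCCC[Se]c1nc(NCc2ccccc2)c2ccccc2n1` — in a functional assay on HT-29 cells (Homo sapiens) for cytotoxicity, read by MTT assay, with a stated time of 72 h (on this read-out lower numbers stand for higher toxicity in this test and higher numbers for lower toxicity in this test), compound 3 gives > 100000 nM, a limit of the assay and not a number.
Compound 2 `Sc1nc(NCc2ccccc2)c2ccccc2n1` — in this assay compound 2 gives > 100000 nM, again a limit.
Compound 1 `CSc1ccc(CNc2nc([SeH])nc3ccccc23)cc1` — in this assay compound 1 gives > 100000 nM, also a limit.

Within the data shown here, compound 3 therefore stands at the limit of this assay, with nothing to rank it against the others: every value so far sits at the limit of > 100000 nM in this assay, at which 3 of the 3 values shown sit. Among the measured compounds shown here, the one step between measured compounds that differ in a single place, a step that the two limits leave unreadable from compound 2 to compound 3, cannot be read because both ends are limits.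

Compound 4 `[SeH]c1nc(NCc2ccccc2)c2ccccc2n1` differs from compound 3 by hydrogen in place of pentyl on a selenium. For the measured compounds named here, no measured step bears on this change. Compound 1, which also carries a selenium bearing hydrogen, gives > 100000 nM, a limit. On these data no step beyond the scatter is expected in this assay, and a further limit is the likeliest outcome. Compound 4 is expected at 100000 nM, within 30000 nM to 300000 nM, which means an estimated step of a number no higher from compound 3 to compound 4 (the limit leaves the size open).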

Compound 4, concentration lethal to 50% of the cells: > 100000 nM
Compound 4: a limit, no number (the forecaster's own chance of this, stated with the estimate: 85%); the middle value sits exactly at the limit.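

In this assay compound 4 gives > 100000 nM, a limit and not a number. No step from compound 1, compound 2 or compound 3 to compound 4 can be read: the limit of > 100000 nM in this assay, at which 4 of the 4 values shown sit.

The compounds shown leave open whether selenium in place of sulfur, or any substituent on selenium, changes toxicity in this test.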